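Allyl to Cyclohexyl on the Enaminone Nitrogen

The compounds below may be only part of what the source reports. "The series", "measured", "known", "first", "only" and "open" are said of these compounds alone.

Measured compounds:
- compound 1 `C=CCNC(=C\C(=O)/C=C/c1ccc(O)c(OC)c1)/C=C/c1ccc(O)c(OC)c1`: 76%
- compound 2 `COc1cc(/C=C/C(=O)/C=C(/C=C/c2ccc(OC(C)=O)c(OC)c2)NC2CCCCC2)ccc1OC(C)=O`: 62%
- compound 3 `CC(C)CNC(=C\C(=O)/C=C/c1ccc(O)cc1)/C=C/c1ccc(O)cc1`: 82%

Of the compounds shown here, three sharing a bis-styryl enaminone core have been tested in a functional assay on Caco-2 cells (Homo sapiens), read by fluorescence, tested at 10 uM; a lower number here means a stronger effect, a higher number a weaker effect of the compound at the concentration tested. Compound 1 stands second highest of the three numbers. Its nearest neighbour is compound 3, whose value is higher by an amount that lies within the scatter, so no order between compound 1 and compound 3 can be read from these two numbers. For the measured compounds named here, compound 2 lies lowest, and its distance from compound 1 is beyond the scatter; compound 2, however, differs from compound 1 in more than one place, so the two values show only that compound 2 gives the stronger effect at this concentration.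

Compound 4 `COc1cc(/C=C/C(=O)/C=C(/C=C/c2ccc(O)c(OC)c2)NC2CCCCC2)ccc1O` has not yet been measured in this assay. It differs from compound 1 in a single place: cyclohexyl in place of allyl on an amine nitrogen

Without a measured step of this kind, the size of the change can only be estimated. Compound 4 is expected to give a slightly lower number than compound 1, a step of a number 6 percentage points lower from compound 1 to compound 4 (within the scatter) that stays within the scatter or just beyond it. For compound 4 the estimate in this assay is 70%, with a range from 56% to 84%.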

Compound 4, a percentage reported as activity, at one concentration (the size of the read-out at that concentration, not a potency): 63%
Beside the measured number, compound 4's estimate is 7 percentage points above it; the range from low to high includes it.
By their numbers in this assay, from the lowest: compounds 2 and 4 (each within the scatter of the next); then compounds 1 and 3 (each within the scatter of the next).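

In this assay, cyclohexyl in place of allyl on the amine nitrogen gives a number 13 percentage points lower from compound 1 to compound 4 (beyond the scatter). For the compounds shown here, this is the first comparison in the set in which only one place changes, and it shows that the group on this nitrogen can shift the read-out at the concentration tested, which the earlier compounds, all differing in more than one place, could not show. The data give no reason for the shift, and nothing measured here bears on its cause.

The change removes a chain with a double bond and brings in a larger saturated ring of carbon only, so the compounds shown leave open whether the lower number goes with the ring, the larger carbon group or the loss of the double bond; a propyl chain, a cyclopentyl ring or a phenyl ring on the same nitrogen would help to separate these. Also open, on these data alone, is how a group carrying an amine or a hydroxyl on this nitrogen would read, and whether the same exchange would give a similar step on the core of compound 3.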